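A few compounds are considered here, and "the series" means these few. Any claim that something is new, unique, unknown or untested is made for them only; others in the source may bear on it.

Measured so far: compound 1 `Cn1ccc2cc(-c3ccc4oc(NC5CCCCC5)nc4c3)ccc21` and compound 2 `NC(=O)Cn1ccc2cc(-c3ccc4oc(NC5CCCCC5)nc4c3)ccc21`. In an assay on HEK293 cells for inhibition of Fatty-acid amide hydrolase 1 (Homo sapiens), read by fluorescence (a higher number here means a weaker inhibitor, a lower number a stronger inhibitor), compound 1 gives 911 nM, and compound 2 gives 214 nM.

For the measured compounds named here, compound 1 has the higher of the two numbers; the only measured step, a 4.3-fold lower number from compound 1 to compound 2 (0.63 log units; beyond the scatter), changes the chain on the aromatic nitrogen, not the part altered here. Compound 3 `Cn1ccc2cc(-c3ccc4oc(Cc5ccccc5)nc4c3)ccc21` differs from compound 1 by benzyl in place of cyclohexylamino on an aromatic carbon. Going by the values given here, no measured step touches this position, so direction and size cannot be read from the data. The expectation for compound 3 is a modest rise, a 2.2-fold higher number from compound 1 to compound 3 (0.34 log units; beyond the scatter), with wide uncertainty: an estimated 2000 nM, plausibly between 400 nM and 10000 nM.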

Compound 3, half-maximal inhibitory concentration: 488 nM
Compound 3: middle estimate off by 4.1-fold (0.61 log units), on the high side; measured number inside the range.
By their numbers in this assay, from the lowest: compound 2; then compounds 3 and 1 (each within the scatter of the next).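

Replacing cyclohexylamino with benzyl on this aromatic carbon gives a 1.9-fold lower number from compound 1 to compound 3 (0.27 log units; within the scatter) in this assay and so shows no clear change in inhibition. At this position, the saturated ring can give way to an aromatic one, and the hydrogen-bond donor and acceptor of cyclohexylamino can go, without a shift larger than the usual scatter. Nothing available explains this result. Still open, on these data alone, is how a phenylamino group, with its nitrogen link kept and an aromatic ring, or a longer chain such as phenylethyl would behave here. Also open, as far as these compounds go, is whether carbamoyl on the chain at the aromatic nitrogen would lower the number with benzyl in place.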